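Aryl Amide Variation at the Amide Nitrogen of Compound 1

A few compounds are considered here, and "the series" means these few. Any claim that something is new, unique, unknown or untested is made for them only; others in the source may bear on it.

Measured compounds:
compound 1 `Cc1ccc(OCC(=O)N(Cc2cccs2)c2cnn(C)c2)cc1`: 63000 nM
compound 2 `CCN(Cc1cccs1)C(=O)c1cc2cc(C)ccc2[nH]1`: 2010 nM
compound 3 `CCN(Cc1cccs1)C(=O)COc1cc(C)ccc1O`: 24 nM

Of the compounds shown here, three have been measured in an assay on HEK293 cells for agonist activity at transient receptor potential cation channel subfamily M member 8 (Homo sapiens), read by fluorescence and calcium flux, with a stated time of 15 min; a higher number here means that more compound is needed for the effect, a lower number that less compound is needed. Compound 1 gives 63000 nM and stands at the highest number of the three, so it needs the most compound for the effect. The nearest number belongs to compound 2, at 2010 nM, and the gap between these two lies beyond the scatter. The furthest is compound 3, at 24 nM, a gap that is also well beyond the scatter.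

The step under consideration goes from compound 1 to compound 4 `Cc1ccc(OCC(=O)N(Cc2cccs2)c2ccccn2)cc1`, which has not yet been measured in this assay. The change is confined to one place: pyridin-2-yl in place of 1-methyl-1H-pyrazol-4-yl on an amide-type nitrogen. Within the data shown here, both groups are aromatic rings of the same heavy-atom count, and no measured pair shows this change, so there is nothing in the data that sets its size or direction. The step from compound 2 to compound 3 shows that the amide region can matter greatly, but those two differ in several places at once.

The author expects the step from compound 1 to compound 4 to be a 2.5-fold lower number from compound 1 to compound 4 (0.40 log units; beyond the scatter), a modest move toward a lower number with wide uncertainty. For compound 4 the estimate is 25000 nM, within the range 4000 nM to 120000 nM.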

Compound 4, half-maximal effective concentration: 200 nM
For compound 4 the middle estimate is 130-fold (2.10 log units) above the measured one; the measured number lies below the stated range.
By their numbers in this assay, from the lowest: compound 3; then compound 4; then compound 2; then compound 1.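

In this assay, among these compounds, the exchange of 1-methyl-1H-pyrazol-4-yl for pyridin-2-yl on the amide-type nitrogen gives a 320-fold lower number from compound 1 to compound 4 (2.50 log units; beyond the scatter) and is the first step here that changes one place only, so it gives the first direct reading of this position. It shows that the group on this nitrogen can, on its own, shift the number by a large amount, even though both groups are aromatic rings with the same heavy-atom count and differ in ring size, hetero atoms and hydrogen-bond acceptors. No measurement shown here bears on which of these differences carries the step or why the step is so large.

The compounds shown leave open whether the step follows from the six-membered ring itself or from the place of its nitrogen, a question that phenyl, pyridin-3-yl or pyrimidin-2-yl on the same nitrogen could address. They also leave open whether the step would hold with the rest of the molecule changed, since compound 2 and compound 3 each differ from compound 1 and compound 4 in more than one place.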